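A few compounds are considered here, and "the series" means these few. Any claim that something is new, unique, unknown or untested is made for them only; others in the source may bear on it.

Working notes on the series. Of the compounds shown here, two have so far been read in a functional assay for antagonist activity at P2X purinoceptor 7 (Rattus norvegicus), read by FLIPR and calcium flux; a lower number here means a stronger inhibitor, a higher number a weaker inhibitor. Compound 1 `COc1ccccc1CNc1ncnn1-c1cccc(Cl)c1Cl` gives 708 nM in this assay. Compound 2 `Clc1cccc(-n2cnnc2NCc2cccnc2)c1Cl` gives 1120 nM in this assay; this is the higher of the two numbers recorded, but the gap to compound 1 lies within the scatter, so the two values show no difference that can be relied on. Among the measured compounds shown here, no step between two measured compounds that differ in a single place has been recorded, so there is no measured change to draw on for the next compound.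

Compound 3 `Clc1cccc(-n2cnnc2NCc2cccnc2N2CCCC2)c1Cl` differs from compound 2 in one place: pyrrolidin-1-yl in place of hydrogen on an aromatic carbon. For the measured compounds named here, with no measured step of comparable kind available, the size of the step in this assay is open; the expectation is a step of modest size, with no direction preferred beyond the scatter, and a wide range is kept. Compound 3 is therefore estimated to come in at 900 nM, with a range from 250 nM to 3500 nM. The step that this estimate means is expected to be a 1.2-fold lower number from compound 2 to compound 3 (0.09 log units; within the scatter).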

Compound 3, half-maximal inhibitory concentration: 12 nM
Estimate against measurement, compound 3: 75-fold (1.88 log units) above; the measured number lies below the stated range.
By their numbers in this assay, from the lowest: compound 3; then compounds 1 and 2 (each within the scatter of the next).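

In this assay, the place on the six-membered aromatic ring with 1 nitrogen, next to the ring nitrogen and ortho to a large group, proves highly responsive to substitution: pyrrolidin-1-yl in place of hydrogen gives a 93-fold lower number from compound 2 to compound 3 (1.97 log units; beyond the scatter) and this large step lies well beyond the scatter. Among the compounds shown here, the earlier compounds supplied no step between compounds differing in one place, so this is the first measured sign that any single change can move the number. It also shows that this crowded place accepts a group of 5 heavy atoms, a five-membered non-aromatic ring with 1 hetero atom, with a strong gain rather than a loss.

Still open, going by these compounds, is whether the gain needs this particular ring or would also appear with a smaller or differently shaped group at the same place, such as dimethylamino, methoxy, piperidin-1-yl or morpholin-4-yl. Nothing available so far bears on why this single change produces a step of this size.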